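From methoxymethyl to isopropoxymethyl on the shared core

The source may report more compounds than this note shows. Statements on the series, on what has been measured and on what is new or still open speak of the compounds shown alone.

Compound 1 `CC1CCN(Cc2cc(Cl)c3cccnc3c2O)CC1`: 1590 nM; 1580 nM (2 entries)
Compound 2 `COCc1cc(CN2CCC(C)CC2)c(O)c2ncccc12`: 4680 nM

Both compounds were measured in a functional assay on MES-SA/Dx5 cells (Homo sapiens) for inhibition, with a stated time of 72 h, in the presence of a further agent that is not named here (a higher number here means a weaker inhibitor, a lower number a stronger inhibitor), and compound 1 gave closely matching repeats (the several entries of compound 1 in this assay, 1590 nM; 1580 nM (2 entries)). For compound 2 the value 4680 nM is the only number shown, and one further entry carries no single number. Within the data shown here, that value is higher than the one for compound 1 (1590 nM; 1580 nM (2 entries)), so compound 2 reads as the weaker inhibitor of the two.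

Compound 3 `CC1CCN(Cc2cc(COC(C)C)c3cccnc3c2O)CC1` has isopropyl in place of methyl on an oxygen on a saturated carbon, which turns methoxymethyl to isopropoxymethyl. Among the measured compounds shown here, no measured pair shows this change, and no step beyond the usual scatter is expected in this assay. The estimated step (a 1.2-fold lower number from compound 2 to compound 3 (0.09 log units; within the scatter)) is therefore small. Compound 3 is expected at 3800 nM (1400 nM to 9500 nM).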

Compound 3, half-maximal inhibitory concentration: 2140 nM
For compound 3 the middle estimate is 1.8-fold (0.25 log units) above the measured one; measured number inside the range.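

In this assay, isopropyl in place of methyl on an oxygen on a saturated carbon gives a 2.2-fold lower number from compound 2 to compound 3 (0.34 log units; beyond the scatter). Among these compounds, this is the first measured step at this position, and it shows that the larger isopropyl is accepted there without a loss of inhibition. The step is modest and rests on a single number for compound 2, whose further entry carries no single number, though the close repeats of compound 1 lend the assay some weight: the several entries of compound 1 in this assay, 1590 nM; 1580 nM (2 entries).

The compounds shown leave open whether the trend continues with a longer chain or a benzyl group on that oxygen, or whether a hydroxymethyl or an aminomethyl group could replace the ether altogether. They also leave open whether the step would hold in any other assay.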